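This account rests on a few compounds, and the source may have more. Where it says the series, first, only, none or still open, it means among the compounds named here.

Compounds measured so far, with their numbers in an assay on cells for inhibition of MAP kinase-interacting serine/threonine-protein kinase 1 (Homo sapiens), read by mobility shift assay, with stated times of 10 min and 60 min, in the presence of a further agent that is not named here; on this read-out lower numbers stand for stronger inhibition and higher numbers for weaker inhibition:

Compound 1, `CNC(=O)c1cncc(-c2ccc(C(N)=O)c(OC(C)C)c2)c1`: compound 1 gives 1900 nM
Compound 2, `CC(C)Oc1cc(-c2cncc(-c3cnn(C)c3)c2)ccc1C(N)=O`: compound 2 gives 400 nM
Compound 3, `Cc1n[nH]c(C)c1-c1cncc(-c2ccc(C(N)=O)c(OC(C)C)c2)c1`: compound 3 gives 33 nM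

Compound 3 carries the lowest number of the three, and both of its steps from the others lie beyond the scatter: a 58-fold lower number from compound 1 to compound 3 (1.76 log units; beyond the scatter) and a 12-fold lower number from compound 2 to compound 3 (1.08 log units; beyond the scatter). The step from compound 1 to compound 2, a 4.8-fold lower number from compound 1 to compound 2 (0.68 log units; beyond the scatter), shows that a five-membered ring in this position already helps on its own, and the two steps into compound 3 show that the 3,5-dimethyl-1H-pyrazol-4-yl group adds much more than the 1-methyl-1H-pyrazol-4-yl group.

Compound 4, `CC(C)Oc1cc(-c2cncc(-c3nn[nH]n3)c2)ccc1C(N)=O`, has not yet been measured. It differs from compound 3 in one place: 2H-tetrazol-5-yl in place of 3,5-dimethyl-1H-pyrazol-4-yl on an aromatic carbon. Among the compounds with values here, no measured pair shows this ring in this position, so the expectation rests on the three steps above, which all point to the 3,5-dimethyl-1H-pyrazol-4-yl group as the source of the gain seen in compound 3. Removing it is therefore expected to cost potency, with compound 4 estimated at 500 nM (range 100 nM to 3000 nM), a step of a 15-fold higher number from compound 3 to compound 4 (1.18 log units; beyond the scatter).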

Compound 4, half-maximal inhibitory concentration: 310 nM
For compound 4 the middle estimate is 1.6-fold (0.21 log units) above the measured one, within the range that was stated.
By their numbers in this assay, from the lowest: compound 3; then compounds 4 and 2 (each within the scatter of the next); then compound 1.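

In this assay, the 2H-tetrazol-5-yl group does not reach the level of the 3,5-dimethyl-1H-pyrazol-4-yl group (a 9.4-fold higher number from compound 3 to compound 4 (0.97 log units; beyond the scatter)), so at this position a five-membered aromatic ring with a hydrogen-bond donor is not enough on its own to give the result of compound 3. The 2H-tetrazol-5-yl group cannot be told apart from the 1-methyl-1H-pyrazol-4-yl group (a 1.3-fold lower number from compound 2 to compound 4 (0.11 log units; within the scatter)), yet it still improves on the methylcarbamoyl group (a 6.1-fold lower number from compound 1 to compound 4 (0.79 log units; beyond the scatter)), which shows that rings with different numbers of hetero atoms can read alike here. No measurement is available that would account for these differences.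

The compounds shown leave open what an unsubstituted 1H-pyrazol-4-yl group would give here, and so how much the two methyl groups contribute. They also leave open how a carboxylic acid or an amine would read at this position.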